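Cytotoxicity in prostate cells: swapping a pyrrolidinylmethyl for an oxazolyl

The source may report more compounds than this note shows. Statements on the series, on what has been measured and on what is new or still open speak of the compounds shown alone.

Measured so far:
- compound 1, `O=C(Nc1cccc(CN2CCCC2)c1)C1CCCN(C(=O)c2cc(C(F)(F)F)cc(C(F)(F)F)c2)C1`, 51%
- compound 2, `O=C(Nc1cccc(Cc2ccccc2)c1)C1CCCN(C(=O)c2cccc(-c3ccco3)c2)C1`, 0%
- compound 3, `COCc1cccc(C(=O)N2CCCC(C(=O)Nc3ccc(Cl)cc3)C2)c1`, 0%

Of the compounds shown here, three sharing a piperidine-carboxamide core have been tested in an ADME assay on PC-3 cells (Homo sapiens) for cytotoxicity, read by WST assay, tested at 100 uM; a lower number here means less inhibition, a higher number more inhibition at the concentration tested (going by the name of the read-out). Compound 1 stands highest of the three: in this assay compound 1 gives 51%, which lies beyond the scatter above the values of compound 2 and compound 3, both of which show no inhibition at all.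

The next compound to be measured is compound 4, `O=C(Nc1cccc(-c2cnco2)c1)C1CCCN(C(=O)c2cc(C(F)(F)F)cc(C(F)(F)F)c2)C1`. It differs from compound 1 in a single place: 1,3-oxazol-5-yl in place of (pyrrolidin-1-yl)methyl on an aromatic carbon. Among the compounds with values here, no pair of measured compounds differing in only one place is available, so the size of this step has to be guessed from the three values alone. Compound 2 and compound 3, neither of which carries the (pyrrolidin-1-yl)methyl group, both give no inhibition in this assay, so compound 4 is expected to fall, by a step of a number 31 percentage points lower from compound 1 to compound 4 (beyond the scatter), downward and beyond the scatter. Compound 4 is therefore estimated at 20%, within a range from 0% to 50%.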

Compound 4, a percentage reported as inhibition, at one concentration (the size of the read-out at that concentration, not a potency): 9%
Compound 4: the middle estimate sits 11 percentage points above what was measured; measured number inside the range.
By their numbers in this assay, from the lowest: compounds 2, 3 and 4 (each within the scatter of the next); then compound 1.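

In this assay, within the data shown here, placing 1,3-oxazol-5-yl instead of (pyrrolidin-1-yl)methyl on this aromatic carbon gives a number 42 percentage points lower from compound 1 to compound 4 (beyond the scatter), the first comparison in this set that isolates a single change. As the rest of the structure is the same, the inhibition seen with compound 1 does not come from the remainder of the molecule alone, but depends on the group at this position. No measurement available here explains the size of this step.

Still open, from the compounds shown here alone, is whether another amine at this position, such as (piperidin-1-yl)methyl or (dimethylamino)methyl, would retain the inhibition, or whether a non-aromatic ring without nitrogen, such as cyclopentylmethyl, would do the same. Going by these compounds, it is also open whether (pyrrolidin-1-yl)methyl would give a similar result when the two trifluoromethyl groups are replaced by chlorine atoms.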